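The compounds below may be only part of what the source reports. "The series", "measured", "known", "first", "only" and "open" are said of these compounds alone.

Measured so far:
- compound 1 `Cc1ccc(-c2ccc(F)cc2)n1-c1ccc(-c2nc3ccccc3s2)cc1`: 3180 nM
- compound 2 `Cc1ccc(-c2ccc(C)n2-c2ccc(-c3nc4ccc(F)cc4s3)cc2)cc1`: 2970 nM

Both were tested in a functional assay on MCF7 cells (Homo sapiens) for cytotoxicity, read by MTT assay, with a stated time of 72 h; on this read-out lower numbers stand for stronger inhibition and higher numbers for weaker inhibition. Compound 2 gives the lowest of the two numbers, but compound 1 sits so close that the two cannot be told apart within the usual scatter. Compound 3 `Cc1ccc(-c2ccc(F)cc2)n1-c1ccc(-c2nc3ccc(F)cc3s2)cc1` has not been measured yet. It differs from compound 2 in one place: fluoro in place of methyl on an aromatic carbon; read one bond further out, this is 4-methylphenyl to 4-fluorophenyl. Among the compounds with values here, no pair of measured compounds shows this step on its own. Compound 1, however, already carries the 4-fluorophenyl group and gives 3180 nM, close to what compound 2 gives at 2970 nM. From compound 2 to compound 3 the expected change is a 1.0-fold higher number from compound 2 to compound 3 (0.00 log units; within the scatter), none beyond the scatter. Compound 3 is therefore estimated at 3000 nM, with a range from 1500 nM to 6000 nM.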

Compound 3, half-maximal inhibitory concentration: 2800 nM
Compound 3: the middle estimate sits 1.1-fold (0.03 log units) above what was measured, and the stated range covers the measured number.
By their numbers in this assay, from the lowest: compounds 3, 2 and 1 (each within the scatter of the next).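

In this assay the swap of methyl for fluoro on the six-membered aromatic ring, para to a large group, can now be read as a single change and gives a 1.1-fold lower number from compound 2 to compound 3 (0.03 log units; within the scatter) so in this assay the two groups cannot be told apart at this position. A second single change, the addition of a fluoro group elsewhere in the molecule, gives a 1.1-fold lower number from compound 1 to compound 3 (0.06 log units; within the scatter) and so also stays inside the usual scatter. Nothing available here explains why neither change moves the number.

On these data alone, it remains open whether a very different group at the same position, such as an amine, a carboxylic acid or a longer chain, would move the number beyond the scatter. The three compounds also leave open whether either of these two results would hold on a different core.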